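Chloro in Place of Trifluoromethyl: What Compound 4 Should Show

A few compounds are considered here, and "the series" means these few. Any claim that something is new, unique, unknown or untested is made for them only; others in the source may bear on it.

Compound 1 `Nc1scc(CN2CCN(c3ccccc3C(F)(F)F)CC2)c1C(=O)c1ccc(Cl)cc1`: -39%
Compound 2 `Nc1scc(CN2CCN(c3cccnc3)CC2)c1C(=O)c1ccc(Cl)cc1`: -2.7%
Compound 3 `Nc1scc(CN2CCN(c3c(F)cc(F)cc3F)CC2)c1C(=O)c1ccc(Cl)cc1`: -56%

In a functional assay on CHO cells with adenosine receptor A1 (Homo sapiens) as the target, read by cAMP accumulation and immunoassay, with a stated time of 6 min, tested at 1 uM (a lower number here means a stronger effect, a higher number a weaker effect of the compound at the concentration tested), compound 1 gives -39%, the second highest of the three numbers: compound 3 lies a number 17 percentage points lower from compound 1 to compound 3 (beyond the scatter), compound 2 lies a number 36.3 percentage points higher from compound 1 to compound 2 (beyond the scatter). Compound 4 `Nc1scc(CN2CCN(c3ccccc3Cl)CC2)c1C(=O)c1ccc(Cl)cc1` differs from compound 1 only by chloro in place of trifluoromethyl on an aromatic carbon. For the measured compounds named here, no measured step changes just this group; the steps from compound 1 replace the whole aryl group, so they bear on it only loosely. Both aryl groups with substituents near the ring nitrogen, compound 1 and compound 3, gave clearly negative numbers, while the pyridin-3-yl of compound 2 gave almost none. Compound 4 keeps such an aryl group, so the expected step is estimated as a number 1 percentage points lower from compound 1 to compound 4 (within the scatter). Compound 4 is thus estimated at -40%, with a range from -62% to -15%.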

Compound 4, a percentage reported as activity, at one concentration (the size of the read-out at that concentration, not a potency): -5.2%
Estimate against measurement, compound 4: 34.8 percentage points below; the whole stated range lies below it.
By their numbers in this assay, from the lowest: compound 3; then compound 1; then compounds 4 and 2 (each within the scatter of the next).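

Chloro in place of trifluoromethyl alone gives a number 33.8 percentage points higher from compound 1 to compound 4 (beyond the scatter) in this assay and so shows that a substituent at this place, ortho to a large group, does not secure a clearly negative number by its presence: the identity of the group matters. Against the other aryl groups there is a number 50.8 percentage points higher from compound 3 to compound 4 (beyond the scatter) and a number 2.5 percentage points lower from compound 2 to compound 4 (within the scatter) and so the 2-chlorophenyl group does not separate from pyridin-3-yl here. Nothing measured here explains this difference between chloro and trifluoromethyl. From the compounds shown here alone, whether a methyl or a methoxy at this place would read like trifluoromethyl or like chloro stays open.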